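The compounds below may be only part of what the source reports. "The series", "measured", "known", "first", "only" and "open" are said of these compounds alone.

Measured so far:
- compound 1 `O=C(CCC(NS(=O)(=O)c1ccc(Br)cc1)C(=O)NC1CCCCC1)NC1CCCCC1`: 18.4%
- compound 2 `O=C(CCC(NS(=O)(=O)c1ccc(Cl)c(Cl)c1)C(=O)NC1CCCCC1)NC1CCCCC1`: 24%
- compound 3 `CCCCNC(=O)CCC(NS(=O)(=O)c1cc(C)ccc1Cl)C(=O)NCCCC`: 18%

In a functional assay on IMR-32 cells (Homo sapiens) for cytotoxicity, read by MTT assay, tested at 60 ug/mL (on this read-out lower numbers stand for less inhibition and higher numbers for more inhibition at the one concentration tested (going by the name of the read-out)), compound 2 stands at the top of these three numbers, yet its gaps to compound 1 and to compound 3 both lie within the scatter, so the three cannot be told apart. Compound 4 `Cc1ccc(Cl)c(S(=O)(=O)NC(CCC(=O)NC2CCCCC2)C(=O)NC2CCCCC2)c1` differs from compound 2 in one place: 2-chloro-5-methylphenyl in place of 3,4-dichlorophenyl on a sulfonyl sulfur. For the measured compounds named here, the one measured step that bears on this, an exchange of the aryl group on the sulfonyl sulfur, is a number 5.6 percentage points higher from compound 1 to compound 2 (within the scatter). Compound 3, which already carries the 2-chloro-5-methylphenyl group, gives 18%. A step of no more than the scatter is therefore expected for a number 4 percentage points lower from compound 2 to compound 4 (within the scatter). Compound 4 is estimated at 20%, within 9% to 32%.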

Compound 4, a percentage reported as inhibition, at one concentration (the size of the read-out at that concentration, not a potency): 49.7%
Beside the measured number, compound 4's estimate is 29.7 percentage points below it, outside the stated range (above it).
By their numbers in this assay, from the lowest: compounds 3, 1 and 2 (each within the scatter of the next); then compound 4.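

In this assay, the aryl group on the sulfonyl sulfur clearly matters with the cyclohexyl amides in place. Putting 2-chloro-5-methylphenyl there gives a number 25.7 percentage points higher from compound 2 to compound 4 (beyond the scatter) and a number 31.3 percentage points higher from compound 1 to compound 4 (beyond the scatter), whereas the earlier exchange at this position stayed within the scatter. No evidence here explains why this group stands apart.

The compounds shown leave open whether the step needs both the chlorine and the methyl of 2-chloro-5-methylphenyl. Going by these compounds, how a methoxy group or a carboxylic acid in place of that methyl would read also remains open.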